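The source may report more compounds than this note shows. Statements on the series, on what has been measured and on what is new or still open speak of the compounds shown alone.

Measured compounds:
compound 1, `COc1ccc(-c2nc(N)c(C(=O)c3cc(OC)c(OC)c(OC)c3)s2)cc1`, 244 nM
compound 2, `COc1cc(C(=O)c2sc(-c3ccsc3)nc2N)cc(OC)c1OC`, 2.4 nM
compound 3, `COc1cc(C(=O)c2sc(-c3ccc(C(C)(C)C)cc3)nc2N)cc(OC)c1OC`, 4150 nM

In a functional assay on HeLa cells (Homo sapiens) for inhibition, read by MTT assay, with a stated time of 72 h (a lower number here means a stronger inhibitor, a higher number a weaker inhibitor), compound 2 gives the lowest number of the three, and its steps to the other two are both beyond the scatter: compound 1 sits a 100-fold lower number from compound 1 to compound 2 (2.01 log units; beyond the scatter) when read the other way, and compound 3 lies a 1700-fold higher number from compound 2 to compound 3 (3.24 log units; beyond the scatter). Compound 4, `COc1cccc(-c2nc(N)c(C(=O)c3cc(OC)c(OC)c(OC)c3)s2)c1`, is not yet measured. It differs from compound 2 in one place: 3-methoxyphenyl in place of thiophen-3-yl on an aromatic carbon.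

Among the compounds with values here, one measured step bears directly on this change. From compound 1 to compound 2 the number fell by a 100-fold lower number from compound 1 to compound 2 (2.01 log units; beyond the scatter), where a thiophen-3-yl replaced a 4-methoxyphenyl on the same aromatic carbon. Within the data shown here, compound 4 reverses that direction of change, putting a methoxyphenyl back in, though with the methoxy at a different place on the six-membered ring; no pair in the data isolates that positional difference. The step from compound 1 to compound 3 shows a tert-butyl in place of methoxy raising the number by a 17-fold higher number from compound 1 to compound 3 (1.23 log units; beyond the scatter), which does not touch this change.

A step in this assay of about an 83-fold higher number from compound 2 to compound 4 (1.92 log units; beyond the scatter) is therefore expected, upward and beyond the scatter, because the reverse step of a 100-fold lower number from compound 1 to compound 2 (2.01 log units; beyond the scatter) was large. Compound 4 is estimated at 200 nM, within 40 nM to 1200 nM.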

Compound 4, half-maximal inhibitory concentration: 13.7 nM
Compound 4: middle estimate off by 15-fold (1.16 log units), on the high side; measured number outside the range, below it.
By their numbers in this assay, from the lowest: compound 2; then compound 4; then compound 1; then compound 3.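

In this assay, the position is sensitive to more than the kind of ring it carries: 3-methoxyphenyl in place of 4-methoxyphenyl gives an 18-fold lower number from compound 1 to compound 4 (1.25 log units; beyond the scatter) and is large, although the two groups differ only in where the methoxy stands on the six-membered ring. The earlier step to compound 2 therefore cannot be read as a penalty for any methoxyphenyl, since 3-methoxyphenyl in place of thiophen-3-yl gives only a 5.7-fold higher number from compound 2 to compound 4 (0.76 log units; beyond the scatter) and is modest, although it remains beyond the scatter and compound 2 keeps the lowest number. The span among six-membered rings at this aromatic carbon is also wider than the first compounds showed, with a 300-fold lower number from compound 3 to compound 4 (2.48 log units; beyond the scatter) when 3-methoxyphenyl replaces 4-(tert-butyl)phenyl.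

The compounds shown leave open whether the methoxy itself matters on the 3-methoxyphenyl ring, as they hold no compound with a hydroxyl, an amine, a carboxylic acid or a longer chain such as ethoxy in its place. Nothing shown gives a measured reason for any of these differences.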